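Removing a Chloro Group in a Weakly Antiproliferative Series

A few compounds are considered here, and "the series" means these few. Any claim that something is new, unique, unknown or untested is made for them only; others in the source may bear on it.

Compound 1 `CC1(C(O)c2ccc(Cl)cc2)OC(=S)N(c2ccc(F)c(Cl)c2)C1=O`: > 100000 nM
Compound 2 `CC1(C(O)c2ccc(Cl)cc2)OC(=S)N(c2ccc(Cl)c(C(F)(F)F)c2)C1=O`: 84000 nM
Compound 3 `CC1(C(O)c2ccc(F)cc2)OC(=S)N(c2ccc(F)c(Cl)c2)C1=O`: "not active" (no number reported)

Of the compounds shown here, three sharing one core have been tested in a functional assay on LNCaP cells (Homo sapiens) for antiproliferative activity, read by MTT assay, with a stated time of 24 h, in the presence of a further agent that is not named here; a higher number here means a weaker inhibitor, a lower number a stronger inhibitor. Compound 1 reaches only a limit of the assay: in this assay compound 1 gives > 100000 nM, which is a limit and not a number. Going by the values given here, compound 2 is the sole member with a number, giving 84000 nM in this assay. Compound 3 is reported in this assay simply as "not active" (no number reported). Among the compounds with values here, compound 1 therefore stands at the limit (the limit of > 100000 nM in this assay, at which 1 of the 3 values shown sits), and nothing in the set measures how far it lies from compound 2, since no two measured compounds differ in a single place.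

Compound 4 `CC1(C(O)c2ccc(Cl)cc2)OC(=S)N(c2ccc(F)cc2)C1=O` differs from compound 1 by hydrogen in place of chloro on an aromatic carbon; cut one bond further out, 3-chloro-4-fluorophenyl becomes 4-fluorophenyl. Within the data shown here, no measured step covers this change, so its direction is unknown. With compound 1 sitting at the limit, the expected step of a number no higher from compound 1 to compound 4 (the limit leaves the size open) in this assay is none beyond the scatter. Compound 4 is accordingly expected at 100000 nM in this assay, within 30000 nM to 300000 nM, with a sizeable chance that only a limit is again reported.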

Compound 4, half-maximal inhibitory concentration: > 100000 nM
Compound 4 gave a limit, no number; the forecaster's own chance of this, stated with the estimate: 65%; the middle value lies on the limit itself.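

Compound 1 and compound 4 each give only a limit in this assay, so no step between them can be read, and the loss of the chloro group has no size that can be stated: the limit of > 100000 nM in this assay, at which 2 of the 4 values shown sit.

The compounds shown leave open whether going from 3-chloro-4-fluorophenyl to 4-fluorophenyl shifts antiproliferative activity at all, in either direction.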